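Removing the aryl chloro from compound 1

A few compounds are considered here, and "the series" means these few. Any claim that something is new, unique, unknown or untested is made for them only; others in the source may bear on it.

In a functional assay for inhibition of metabotropic glutamate receptor 5 (Homo sapiens), read by FLIPR and calcium flux (a lower number here means a stronger inhibitor, a higher number a weaker inhibitor), compound 1 `Cc1cccc(C#CCCc2cccc(Cl)c2)n1` gives 5 nM, the lower of the two numbers recorded so far; compound 2 `Cc1cccc(C#CCSc2cccc(Cl)c2)n1` gives 43 nM, a higher number that lies beyond the scatter. Compound 3 `Cc1cccc(C#CCCc2ccccc2)n1` differs from compound 1 by hydrogen in place of chloro on an aromatic carbon. Among the compounds with values here, no step between measured compounds covers this change, so the series offers no direct precedent. A modest weakening is expected, with the step of a 4.0-fold higher number from compound 1 to compound 3 (0.60 log units; beyond the scatter) beyond the usual scatter. Compound 3 is estimated at 20 nM, within 8 nM to 60 nM.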

Compound 3, half-maximal inhibitory concentration: 78 nM
The estimate for compound 3 lay 3.9-fold (0.59 log units) below the measured number, outside the stated range (above it).
By their numbers in this assay, from the lowest: compound 1; then compounds 2 and 3 (each within the scatter of the next).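

In this assay, within the data shown here, hydrogen in place of chloro on an aromatic carbon gives a 16-fold higher number from compound 1 to compound 3 (1.19 log units; beyond the scatter), the first step at this position, meta to a large group. The change removes only one chlorine atom, with no ring, no hydrogen-bond donor or acceptor and no net charge involved, yet the step is large. No measured data bear on why it is this large.

Going by these compounds, whether fluoro, bromo or methyl at this position would match chloro stays open. So does whether the same change on compound 2 would give a step of similar size.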